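Pyrrolidin-1-yl replaces dipropylamino on a weakly active core

The compounds below may be only part of what the source reports. "The series", "measured", "known", "first", "only" and "open" are said of these compounds alone.

In a functional assay on MCF7 cells (Homo sapiens) for inhibition, read by sulforhodamine B assay (a higher number here means a weaker inhibitor, a lower number a stronger inhibitor), compound 1 `O=C1C=C(Nc2ccccc2F)C(=O)c2c1nc1n2[C@H]2OC[C@@H](O)[C@H]2OC1` gives 3640 nM. Compound 2 `COc1ccccc1NC1=CC(=O)c2nc3n(c2C1=O)[C@H]1OC[C@@H](O)[C@H]1OC3` is recorded only as a limit, > 4000 nM. Compound 3 `CCCN(CCC)C1=CC(=O)c2nc3n(c2C1=O)[C@H]1OC[C@@H](O)[C@H]1OC3` is also recorded only as a limit, > 16000 nM. Compound 4 `O=C1C=C(N2CCCC2)C(=O)c2c1nc1n2[C@H]2OC[C@@H](O)[C@H]2OC1` differs from compound 3 by one change, pyrrolidin-1-yl in place of dipropylamino on a double-bonded ring carbon. Among the measured compounds shown here, the one readable step at this place is an at least 4.3-fold higher number from compound 1 to compound 3 (0.64 log units; beyond the scatter), where dipropylamino replaces (2-fluorophenyl)amino. By contrast, a step that the two limits leave unreadable from compound 2 to compound 3. For the measured compounds named here, compound 4 also lacks a phenylamino group, and no measured step swaps one non-aromatic amino group for another, so no change beyond the scatter is expected in this assay. The expected step is a number no higher from compound 3 to compound 4 (the limit leaves the size open). For compound 4 the estimated value is 16000 nM, with an expected range of 5000 nM to 50000 nM.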

Compound 4, half-maximal inhibitory concentration: > 16000 nM
Compound 4: only a limit was reported (the forecaster's own chance of this, stated with the estimate: 50%); the middle value sits exactly at the limit.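

In this assay compound 4 is recorded only as a limit of > 16000 nM and is the second non-aromatic amino group on this double-bonded ring carbon to end at that limit: the limit of > 16000 nM in this assay, at which 2 of the 4 values shown sit. The five-membered pyrrolidin-1-yl ring in place of (2-fluorophenyl)amino gives an at least 4.3-fold higher number from compound 1 to compound 4 (0.64 log units; beyond the scatter) and so shows that the step beyond the scatter is not confined to dipropylamino. The steps to compound 4 from compound 2 and compound 3 cannot be read.

Going by these compounds, whether pyrrolidin-1-yl and dipropylamino differ at all stays open, as neither has a number. Also open, on these data alone, is whether morpholin-4-yl or dimethylamino at this carbon would give a value inside the assay's range.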